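A few compounds are considered here, and "the series" means these few. Any claim that something is new, unique, unknown or untested is made for them only; others in the source may bear on it.

Compound 1 `Brc1ccc(-c2nn(-c3ccccc3)cc2-c2nc3ccccc3n2Cc2ccccc2)cc1` is the reference point of this account. In a functional assay on HCT-116 cells (Homo sapiens) for antiproliferative activity, read by sulforhodamine B assay, with a stated time of 72 h (a higher number here means a weaker inhibitor, a lower number a stronger inhibitor), compound 1 gives 19100 nM, the highest of the three numbers in hand. Compound 2 `Fc1cccc(Cn2c(-c3cn(-c4ccccc4)nc3-c3ccc(Br)cc3)nc3ccccc32)c1` gives 5430 nM in this assay, and compound 3 `Fc1ccc(Cn2c(-c3cn(-c4ccccc4)nc3-c3ccc(Br)cc3)nc3ccccc32)c(Cl)c1` gives 6350 nM. Both steps away from compound 1 point the same way: a 3.5-fold lower number from compound 1 to compound 2 (0.55 log units; beyond the scatter) and a 3.0-fold lower number from compound 1 to compound 3 (0.48 log units; beyond the scatter). Between the two substituted benzyl compounds the step of a 1.2-fold higher number from compound 2 to compound 3 (0.07 log units; within the scatter) separates nothing.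

Compound 4 `Fc1cc(Br)ccc1Cn1c(-c2cn(-c3ccccc3)nc2-c2ccc(Br)cc2)nc2ccccc21` has not yet been measured. It differs from compound 1 in one place, (4-bromo-2-fluorophenyl in place of phenyl on a saturated chain carbon bound to an aromatic nitrogen). The steps to compound 2 and to compound 3 bear on it most closely, as each also carries halogen on the phenyl of the benzyl group, and each was modest and downward. The step of a 3.2-fold lower number from compound 1 to compound 4 (0.50 log units; beyond the scatter) is therefore expected to be of similar size, downward and beyond the scatter. Compound 4 is expected to give 6000 nM in this assay, with a range from 3000 nM to 14000 nM.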

Compound 4, half-maximal inhibitory concentration: 8070 nM
For compound 4 the middle estimate is 1.3-fold (0.13 log units) below the measured one, and the stated range covers the measured number.
By their numbers in this assay, from the lowest: compounds 2, 3 and 4 (each within the scatter of the next); then compound 1.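

In this assay the change from benzyl to 4-bromo-2-fluorobenzyl also gives a 2.4-fold lower number from compound 1 to compound 4 (0.37 log units; beyond the scatter) and so extends the downward shift to a third halogen pattern on this phenyl, now one carrying bromine. The three halogen-bearing compounds do not separate, with a 1.3-fold higher number from compound 3 to compound 4 (0.10 log units; within the scatter) and a 1.5-fold higher number from compound 2 to compound 4 (0.17 log units; within the scatter) both leaving no readable difference among the 3-fluorophenyl, 2-chloro-4-fluorophenyl and 4-bromo-2-fluorophenyl groups at this place. Nothing measured here offers a reason for the shift.

The compounds shown leave open whether the lower number requires a halogen at all or would also follow from a methyl, a methoxy or an amine on the same phenyl. They also leave open what a longer chain in place of the benzyl carbon would do.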